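Swapping the Aryl Amine on an Inactive Chalcone Thiazole

This account rests on a few compounds, and the source may have more. Where it says the series, first, only, none or still open, it means among the compounds named here.

Compound 2 `COc1cc(/C=C/C(=O)c2sc(Nc3ccc(Cl)c(Cl)c3)nc2C)cc(OC)c1OC` was tested in a functional assay on Bel-7402 cells (Homo sapiens) for cytotoxicity, read by MTT assay; on this read-out higher numbers stand for weaker inhibition and lower numbers for stronger inhibition. In this assay compound 2 reached only the limit of > 25000 nM, which marks the edge of the measurement rather than a true number. Compound 1 `Cc1ccccc1Nc1nc(C)c(C(=O)/C=C/c2ccccc2)s1` likewise stopped at the limit of > 25000 nM in this assay. Within the data shown here, both measured values thus rest at the same place, (the limit of > 25000 nM in this assay, at which 2 of the 2 values shown sit), so no step between measured compounds can be sized, and where compound 2 stands is known only as a ceiling.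

Compound 3 `COc1cc(/C=C/C(=O)c2sc(Nc3ccccc3C)nc2C)cc(OC)c1OC` has not yet been measured. It differs from compound 2 in one way: 2-methylphenyl in place of 3,4-dichlorophenyl on a nitrogen on an aromatic ring. Compound 1 already carries this 2-methylphenyl group on the same nitrogen, and its result in this assay was also a limit. The step from compound 2 to compound 3 is expected to be a step that the limit leaves unreadable from compound 2 to compound 3, no change beyond the scatter. Compound 3 is expected to give 40000 nM, within 15000 nM to 150000 nM, most likely reported again only as a limit.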

Compound 3, half-maximal inhibitory concentration: 10300 nM
For compound 3 the middle estimate is 3.9-fold (0.59 log units) above the measured one; measured number outside the range, below it.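

Among these compounds, on the nitrogen on an aromatic ring, the choice of aryl group does matter: in this assay, 2-methylphenyl in place of 3,4-dichlorophenyl gives an at least 2.4-fold lower number from compound 2 to compound 3 (0.38 log units; beyond the scatter), and compound 3 is the first compound here with a true number. That size is only a minimum, as the starting value is not a true number: the limit of > 25000 nM in this assay, at which 2 of the 3 values shown sit.

Compound 1 carries the same 2-methylphenyl group yet gives only a limit, > 25000 nM, so this group alone does not guarantee a measurable value.

The compounds shown leave open whether the change comes from gaining the methyl group or from losing the two chlorines. They also do not tell how a plain phenyl or a pyridine ring on the same nitrogen would compare.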